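The compounds below may be only part of what the source reports. "The series", "measured", "known", "first", "only" and "open" are said of these compounds alone.

Compound 1 `N#Cc1cnc(NCc2cnccc2C(F)(F)F)cc1N[C@H]1C[C@H](O)C1` gives 900 nM in an assay on isolated protein for inhibition of protein kinase C theta type (Homo sapiens), read by TR-FRET, with a stated time of 2 h; on this read-out higher numbers stand for weaker inhibition and lower numbers for stronger inhibition.
Compound 2 `N#Cc1cnc(NCc2cnccc2C(F)(F)F)cc1NCCC1CCOCC1` gives 1200 nM in this assay.

Within the data shown here, compound 2 stands next to compound 1 on these numbers, and the only measured step, a 1.3-fold higher number from compound 1 to compound 2 (0.12 log units; within the scatter), lies within the scatter. Compound 3 `CC1(C)C[C@@H](Nc2cc(NCc3cnccc3C(F)(F)F)ncc2C#N)CC[C@H]1O` differs from compound 2 by 4-hydroxy-3,3-dimethylcyclohexyl in place of 2-(oxan-4-yl)ethyl on a nitrogen on an aromatic ring. That single step is the only one that bears on this change, and it was small, so little beyond the scatter is expected here either. A step of a 1.7-fold lower number from compound 2 to compound 3 (0.23 log units; within the scatter) is expected, back toward the hydroxy-bearing ring of compound 1. Compound 3 is estimated at 700 nM, with a range from 350 nM to 1400 nM.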

Compound 3, half-maximal inhibitory concentration: 120 nM
For compound 3 the middle estimate is 5.8-fold (0.77 log units) above the measured one; the measured number lies below the stated range.
By their numbers in this assay, from the lowest: compound 3; then compounds 1 and 2 (each within the scatter of the next).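

At this nitrogen on an aromatic ring, the substituent proved able to move the number: 4-hydroxy-3,3-dimethylcyclohexyl gives a 10-fold lower number from compound 2 to compound 3 (1.00 log units; beyond the scatter) and a 7.5-fold lower number from compound 1 to compound 3 (0.88 log units; beyond the scatter), whereas the earlier change stayed within the scatter. A hydroxy group alone does not go with the lower number, since compound 1, with its 3-hydroxycyclobutyl, sits within the scatter of compound 2, which has none. Nothing given here explains the difference. Compound 3 changes the ring, the hydroxy group and the two methyl groups together, so their shares stay unseparated. Going by these compounds, whether 4-hydroxycyclohexyl without the methyls, or 4-aminocyclohexyl, would match compound 3 remains open.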